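The compounds below may be only part of what the source reports. "The series", "measured", "known", "first", "only" and "open" are said of these compounds alone.

In a functional assay on MGC-803 cells (Homo sapiens) for inhibition, read by sulforhodamine B assay (a higher number here means a weaker inhibitor, a lower number a stronger inhibitor), compound 1 `COc1ccccc1NC1=CC(=O)c2c(nc3n2[C@H]2OC[C@@H](O)[C@H]2OC3)C1=O` gives 1670 nM. Compound 2 `O=C1C(N2CCCC2)=CC(=O)c2c1nc1n2[C@H]2OC[C@@H](O)[C@H]2OC1` gives > 16000 nM, which is a limit of the assay and not a number. Among the measured compounds shown here, the only measured step, an at least 9.5-fold higher number from compound 1 to compound 2 (0.98 log units; beyond the scatter), puts pyrrolidin-1-yl in place of (2-methoxyphenyl)amino on a double-bonded ring carbon, and it lies beyond the scatter. Compound 3 `O=C1C(N2CCC2)=CC(=O)c2c1nc1n2[C@H]2OC[C@@H](O)[C@H]2OC1` keeps the shared core and changes only the group at that place, with azetidin-1-yl in place of pyrrolidin-1-yl (azetidin-1-yl in place of pyrrolidin-1-yl on a double-bonded ring carbon). For the measured compounds named here, this is a change between two small non-aromatic rings, and no measured step covers such a swap directly. With only an at least 9.5-fold higher number from compound 1 to compound 2 (0.98 log units; beyond the scatter) as a guide, no step beyond the scatter is expected in this assay, so compound 3 should stay weak and may also end at a limit. For compound 3 the expected value is 18000 nM, with an estimated range of 7000 nM to 40000 nM. The estimate means an expected step that the limit leaves unreadable from compound 2 to compound 3.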

Compound 3, half-maximal inhibitory concentration: > 16000 nM
Compound 3: a limit, no number; the forecaster's own chance of this, stated with the estimate: 65%; the middle value lies beyond the limit too.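

In this assay compound 3 gives > 16000 nM, which is a limit of the assay and not a number. Azetidin-1-yl in place of (2-methoxyphenyl)amino gives an at least 9.5-fold higher number from compound 1 to compound 3 (0.98 log units; beyond the scatter), so the loss seen with pyrrolidin-1-yl on the double-bonded ring carbon is not particular to that one ring. Any difference between the two small rings cannot be read, because compound 2 and compound 3 both stand at a limit: the limit of > 16000 nM in this assay, at which 2 of the 3 values shown sit.

The compounds shown leave open whether the aromatic ring or the hydrogen on the nitrogen of the (2-methoxyphenyl)amino group matters more for the value of compound 1. A plain phenylamino group or an open-chain amine such as methylamino at this place would help to separate the two.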